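Swapping the chain end group: estimating cytotoxicity of compound 3

The source may hold more compounds than are shown below. What is called first, only, known or untested is meant among the compounds shown, and "the series" means these compounds.

Measured so far:
compound 1, `NCCNc1cc(N2CCc3ccccc3C2)nc2ccccc12`: 15000 nM
compound 2, `N=C(N)NCCNc1cc(N2CCc3ccccc3C2)nc2ccccc12`: > 100000 nM

In an ADME assay on HEp-2 cells (Homo sapiens) for cytotoxicity, read by CCK-8 assay, with a stated time of 5 days (on this read-out lower numbers stand for higher toxicity in this test and higher numbers for lower toxicity in this test), compound 1 gives 15000 nM. For compound 2 the test reports only a limit, > 100000 nM; this is the limit of > 100000 nM in this assay, at which 1 of the 2 values shown sits, so compound 2 stands at the top of the numbers shown. Compound 3, `NC(=O)NCCNc1cc(N2CCc3ccccc3C2)nc2ccccc12`, differs from compound 2 by a group of 3 heavy atoms (1 carbon, 1 nitrogen, 1 oxygen; no ring) in place of a group of 3 heavy atoms (1 carbon, 2 nitrogen; no ring), on an amine nitrogen. Within the data shown here, the one measured step that bears on this position, an at least 6.6-fold higher number from compound 1 to compound 2 (0.82 log units; beyond the scatter), shows that adding a chain end group there raised the number. Compound 3 keeps a chain end group of the same size, so the number is expected to stay high but is not assured to reach the limit again. Compound 3 is therefore estimated at 60000 nM, within 20000 nM to 150000 nM. That estimate means an at least 1.6-fold lower number from compound 2 to compound 3 (0.22 log units; that floor lies within the scatter), which may be within the scatter.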

Compound 3, half-maximal cytotoxic concentration: 80000 nM
Compound 3: middle estimate off by 1.3-fold (0.12 log units), on the low side; low and high end bracket the measured number.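

In this assay carbamoyl in place of hydrogen on the amine nitrogen also brings a 5.3-fold higher number from compound 1 to compound 3 (0.73 log units; beyond the scatter) and so the higher number does not rest on the end group of compound 2 alone. The swap of that end group for carbamoyl reads as an at least 1.2-fold lower number from compound 2 to compound 3 (0.09 log units; that floor lies within the scatter) and gives only a floor. Its true size stays unknown because compound 2 is recorded only as a limit: the limit of > 100000 nM in this assay, at which 1 of the 3 values shown sits.

From the compounds shown here alone, whether an acetyl group, a methyl group on the end nitrogen or a longer chain would keep the number this high remains open.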